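Adding a Sulfamoyl Group: Expected Cytotoxicity of Compound 3

The compounds below may be only part of what the source reports. "The series", "measured", "known", "first", "only" and "open" are said of these compounds alone.

Compound 1 `Fc1ccc2nc(-c3cc(-c4ccccc4)nn3-c3ccccc3)ccc2c1` gives 126% in an ADME assay on Huh-7 cells (Homo sapiens) for cytotoxicity, read by XTT assay, with a stated time of 3 days, tested at 20 uM; a lower number here means a stronger effect, a higher number a weaker effect of the compound at the concentration tested.
Compound 2 `Fc1ccc(-c2cc(-c3ccc4cc(F)ccc4n3)n(-c3ccccc3)n2)cc1` gives 88.1% in this assay.

Compound 2 stands lowest of these two numbers. Going by the values given here, the only measured step is a number 37.9 percentage points lower from compound 1 to compound 2 (beyond the scatter), a change of fluoro in place of hydrogen on an aromatic carbon. Compound 3 `NS(=O)(=O)c1ccc(-n2nc(-c3ccc(F)cc3)cc2-c2ccc3cc(F)ccc3n2)cc1` differs from compound 2 by sulfamoyl in place of hydrogen on an aromatic carbon. Among the compounds with values here, no measured step involves a sulfamoyl group, so the single known step does not bear on this change. The step from compound 2 to compound 3 is therefore expected to stay within the scatter, a number 3.1 percentage points lower from compound 2 to compound 3 (within the scatter). Compound 3 is estimated at 85%, in the range 60% to 110%.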

Compound 3, a percentage reported as activity, at one concentration (the size of the read-out at that concentration, not a potency): 91.1%
Compound 3: the middle estimate sits 6.1 percentage points below what was measured, and the stated range covers the measured number.
By their numbers in this assay, from the lowest: compounds 2 and 3 (each within the scatter of the next); then compound 1.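

Going from phenyl to 4-sulfamoylphenyl, the read-out in this assay shows a number 3 percentage points higher from compound 2 to compound 3 (within the scatter). This place, para to a large group, therefore carries a sulfamoyl group with no change beyond the usual scatter, whereas the earlier fluoro step, a number 37.9 percentage points lower from compound 1 to compound 2 (beyond the scatter), was beyond it. Nothing on hand gives a reason for this result.

On these data alone, whether an amine or a carboxylic acid at this same place would also leave the read-out within the scatter stays open. So does whether sulfamoyl would behave the same way on compound 1, which lacks the fluoro group.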